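Ring swap on the thiocarbonyl carbon: working notes

The source may report more compounds than this note shows. Statements on the series, on what has been measured and on what is new or still open speak of the compounds shown alone.

Measured so far:
compound 1 `Cc1ccnc(/C(N)=N/NC(=S)N2CCCC2)c1` — 87.7%
compound 2 `Cc1cccc(/C(N)=N/NC(=S)N2CCCC2)n1` — 61.8%
compound 3 `N/C(=N\NC(=S)N1CCCC1)c1ccccn1` — 74.9%

In a functional assay on MCF7 cells (Homo sapiens) for cytotoxicity, read by MTT assay, with a stated time of 72 h, tested at 100 uM (a higher number here means more inhibition of growth at the concentration tested, a lower number less inhibition of growth), compound 1 gives 87.7%, compound 3 gives 74.9% and compound 2 gives 61.8%. Compound 2 stands lowest of the three numbers; its nearest neighbour is compound 3 and its furthest is compound 1, both beyond the scatter. The two steps measured so far both concern hydrogen in place of methyl on an aromatic carbon: a number 12.8 percentage points lower from compound 1 to compound 3 (beyond the scatter) and a number 13.1 percentage points higher from compound 2 to compound 3 (beyond the scatter), each a modest shift.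

Compound 4 `Cc1cccc(/C(N)=N/NC(=S)N2CCSCC2)n1` differs from compound 2 in a different place: thiomorpholin-4-yl in place of pyrrolidin-1-yl on a thiocarbonyl carbon. Neither measured step bears on this change; both touch the aromatic carbon, while the thiocarbonyl carbon carries the same ring in every measured compound. For the measured compounds named here, the series therefore offers no measured step from which a direction or size for this swap can be read. In this assay the expectation is a step of no certain direction and not beyond the scatter, carried with a wide range. Compound 4 is expected to give 62%, between 40% and 82%. The step this estimate means is expected at a number 0.2 percentage points higher from compound 2 to compound 4 (within the scatter).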

Compound 4, percent growth inhibition at one concentration: 46.8%
Compound 4: the middle estimate sits 15.2 percentage points above what was measured; the range from low to high includes it.
By their numbers in this assay, from the lowest: compound 4; then compound 2; then compound 3; then compound 1.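

In this assay, for the compounds shown here, the thiocarbonyl carbon proves to be a place where the number moves: thiomorpholin-4-yl in place of pyrrolidin-1-yl gives a number 15 percentage points lower from compound 2 to compound 4 (beyond the scatter), the first measured step at this position. The earlier compounds shown here showed movement only with hydrogen in place of methyl on an aromatic carbon, as in a number 13.1 percentage points higher from compound 2 to compound 3 (beyond the scatter), so the series now has two places at which a single change carries the number beyond the scatter, and on the background of compound 2 both measured changes have a direction. Nothing at hand says what in the entering ring accounts for the lower number, whether the sulfur, the six-membered ring or something else.

From the compounds shown here alone, this step is read on the core of compound 2 alone, so whether the same swap lowers the number on the cores of compound 1 and compound 3 remains open. Piperidin-1-yl, which has a six-membered ring without the sulfur, and morpholin-4-yl, which has oxygen in place of that sulfur, would each separate ring size from the atom in the ring.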